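The source may hold more compounds than are shown below. What is called first, only, known or untested is meant among the compounds shown, and "the series" means these compounds.

Working notes on the series. Compound 1 `Fc1ccccc1Cn1cc(CSC(=S)N2CCNCC2)nn1` is the starting point of this step. In a functional assay on MGC-803 cells (Homo sapiens) for inhibition, read by MTT assay, with a stated time of 72 h (on this read-out lower numbers stand for stronger inhibition and higher numbers for weaker inhibition), compound 1 gives 19400 nM. Compound 2 `CC(C)(C)OC(=O)N1CCN(C(=S)SCc2cn(Cc3ccc(Cl)cc3)nn2)CC1` gives 9790 nM and compound 3 `O=C(OCc1ccccc1)N1CCN(C(=S)SCc2cn(Cc3ccc(Cl)cc3)nn2)CC1` gives 31300 nM. Among these three numbers compound 1 stands second highest; its gap to compound 3 and its gap to compound 2 both lie within the scatter, so no order among the three can be read.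

For the measured compounds named here, the only step between measured compounds that differ in one place is a 3.2-fold higher number from compound 2 to compound 3 (0.50 log units; beyond the scatter). Compound 4 `Cc1ccc(Cn2cc(CSC(=S)N3CCNCC3)nn2)cc1` arises from compound 1 by 4-methylphenyl in place of 2-fluorophenyl on a saturated chain carbon bound to an aromatic nitrogen. Going by the values given here, this change sits on the saturated chain carbon bound to an aromatic nitrogen, a different part of the molecule from the change in the measured step; compounds 2 and 3 carry yet another group at that carbon, and no two measured compounds differ from each other in that group alone. Among the compounds with values here, no measured step therefore bears on the change from compound 1 to compound 4, and on that basis no step beyond the scatter is expected in this assay. Compound 4 is expected to give 17000 nM, between 7000 nM and 45000 nM, which means an expected step of a 1.1-fold lower number from compound 1 to compound 4 (0.06 log units; within the scatter).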

Compound 4, half-maximal inhibitory concentration: 64300 nM
Compound 4: the middle estimate sits 3.8-fold (0.58 log units) below what was measured; measured number outside the range, above it.
By their numbers in this assay, from the lowest: compounds 2, 1 and 3 (each within the scatter of the next, the first and the last beyond it); then compound 4.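

In this assay, for the compounds shown here, the group on the saturated chain carbon bound to an aromatic nitrogen proves able to shift the number: a 3.3-fold higher number from compound 1 to compound 4 (0.52 log units; beyond the scatter) is the first step read at this place, as the only earlier step lay in another part of the molecule. Both groups have 7 heavy atoms, one six-membered aromatic ring of carbon only, and 0 hydrogen-bond donors or acceptors, so a step beyond the scatter arises here with all of these counts unchanged. Nothing on hand accounts for the size or direction of this step.

The swap removes 2-fluorophenyl and brings in 4-methylphenyl in a single step, so the share of the lost fluorine and that of the added methyl cannot be separated. Going by these compounds, it remains open how an unsubstituted phenyl or a pyridyl ring at this carbon would read against compound 1 and compound 4 in this assay, and whether the step would hold on a core that carries the tert-butyl or benzyl carbamate of compound 2 and compound 3.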